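The compounds below may be only part of what the source reports. "The series", "measured", "known", "first", "only" and "open" are said of these compounds alone.

Working notes on the series. Of the compounds shown here, three of the shared core have been measured. Compound 1 `O=S(=O)(Nc1ccc2oc(-c3ccccc3)nc2c1)c1cccc(C(F)(F)F)c1` gives in an assay on isolated protein for inhibition of malate dehydrogenase, mitochondrial (Sus scrofa), with stated times of 45 min and 30 min (on this read-out higher numbers stand for weaker inhibition and lower numbers for stronger inhibition), the value > 63000 nM, which is a limit of the assay and not a number. Compound 2 `Cc1ccc(S(=O)(=O)Nc2ccc(-c3nc4ccccc4o3)cc2)cc1` likewise stands at a limit: in this assay compound 2 gives > 63000 nM. Compound 3 `O=S(=O)(Nc1ccc(-c2nc3ccccc3o2)cc1)c1ccc(C(F)(F)F)cc1` gives > 63000 nM in this assay, again a limit. Within the data shown here, the only step between compounds differing in one place, a step that the two limits leave unreadable from compound 2 to compound 3, therefore cannot be sized; it is a matter of the limit of > 63000 nM in this assay, at which 3 of the 3 values shown sit.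

Compound 4 `COc1ccc(Cl)cc1S(=O)(=O)Nc1ccc(-c2nc3ccccc3o2)cc1` is not yet measured. It differs from compound 2 by 5-chloro-2-methoxyphenyl in place of 4-methylphenyl on a sulfonyl sulfur. No measured step bears on this change, and the single step shown is itself unreadable, so no direction or size can be drawn from the series. Given that compound 2 sits at the limit, compound 4 is expected to sit there too, with an estimate of 80000 nM and a range from 20000 nM to 300000 nM. The expected step is a step that the limit leaves unreadable from compound 2 to compound 4, most likely not readable at all.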

Compound 4, half-maximal inhibitory concentration: > 63000 nM
Compound 4: only a limit was reported; the forecaster's own chance of this, stated with the estimate: 80%; the middle value is on the limit's open side.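

The step between compound 2 and compound 4 cannot be read, since both stand at a limit of the assay and not at a number: the limit of > 63000 nM in this assay, at which 4 of the 4 values shown sit.

The compounds shown leave open which change to the shared core, if any, would give a measurable value in this assay.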